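The source may hold more compounds than are shown below. What is called first, only, known or untested is meant among the compounds shown, and "the series" means these compounds.

Of the compounds shown here, two from this series have been measured in an assay on isolated protein for inhibition of aldehyde dehydrogenase 1A1 (Homo sapiens), read by spectrophotometry, tested at 10 uM; on this read-out higher numbers stand for more inhibition at the one concentration tested (going by the name of the read-out) and lower numbers for less inhibition. Compound 1, `Cc1cccc(Cn2c(CN3CCN(C(=O)c4ccc(Cl)cc4)CC3)nc3ccccc32)c1`, gives 23.2% in this assay. Compound 2, `Cc1cccc(Cn2c(CN3CCN(C(=O)C4CCCCC4)CC3)nc3ccccc32)c1`, gives 31.9% in this assay, which is the higher of the two numbers, with compound 1 as its nearest neighbour. Going by the values given here, the single measured step, a number 8.7 percentage points higher from compound 1 to compound 2 (within the scatter), lies within the scatter, so it does not separate the two compounds.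

Compound 3 is `Cc1cccc(Cn2c(CN3CCN(C(=O)c4cccs4)CC3)nc3ccccc32)c1`. Relative to compound 2 it carries thiophen-2-yl in place of cyclohexyl on a carbonyl carbon. Among the compounds with values here, no measured step covers this exact exchange; the only step available, from compound 1 to compound 2, swaps one ring for another on the same carbonyl carbon and was within the scatter. On that basis compound 3 is expected to show a number 4.9 percentage points lower from compound 2 to compound 3 (within the scatter) in this assay, that is, no movement beyond the scatter in either direction. Compound 3 is therefore estimated at 27% in this assay, with a range from 12% to 42%.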

Compound 3, a percentage reported as inhibition, at one concentration (the size of the read-out at that concentration, not a potency): 60.8%
Compound 3: middle estimate off by 33.8 percentage points, on the low side; measured number above the stated range.
By their numbers in this assay, from the lowest: compounds 1 and 2 (each within the scatter of the next); then compound 3.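

The group on the carbonyl carbon, which the earlier pair had not shown to matter, does separate compounds in this assay: thiophen-2-yl in place of cyclohexyl gives a number 28.9 percentage points higher from compound 2 to compound 3 (beyond the scatter), and thiophen-2-yl in place of 4-chlorophenyl gives a number 37.6 percentage points higher from compound 1 to compound 3 (beyond the scatter). Both exchanges leave the rest of the molecule untouched, so in these three compounds the change in the read-out follows the group at this one place, with thiophen-2-yl standing apart from cyclohexyl and 4-chlorophenyl, which remain within the scatter of each other. Nothing in the available data accounts for why this group stands apart.

The compounds shown leave open whether the higher number goes with the sulfur atom, with the five-membered aromatic ring or with the point at which that ring is joined to the carbonyl carbon, and a furan-2-yl, a thiophen-3-yl or an unsubstituted phenyl in the same place would bear on this. They also leave open how the three compounds would rank in potency, since each was read at a single concentration.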